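The source may hold more compounds than are shown below. What is called first, only, known or untested is meant among the compounds shown, and "the series" means these compounds.

The study follows a small set of compounds in an in vitro ADME assay on microsomes from liver (Mus musculus) for metabolic stability; on this read-out higher numbers stand for a longer-lived compound and lower numbers for a shorter-lived compound. Compound 1 (`O=C1COCCN1c1ccc(C2CC(c3ccc([N+](=O)[O-])o3)=NO2)cn1`) gives 1.01 h, and compound 2 (`O=C1COCCN1c1ccc(C2CC(c3ccc([N+](=O)[O-])o3)=NO2)cc1F`) gives 1.38 h. Among the measured compounds shown here, these two values lie within the scatter of each other, so compound 1 stands level with the only other number available.

The next compound to be read is compound 3 (`CN1CCN(c2ccc(C3CC(c4ccc([N+](=O)[O-])o4)=NO3)cn2)C(=O)C1`). It keeps the core of compound 1 but carries 4-methyl-2-oxopiperazin-1-yl in place of 3-oxomorpholin-4-yl on an aromatic carbon, next to the ring nitrogen and para to a large group: 4-methyl-2-oxopiperazin-1-yl in place of 3-oxomorpholin-4-yl on an aromatic carbon. For the measured compounds named here, no measured pair shows what a change at this place does to this assay, so the data offer no direct guide to its size. Only a small step towards a shorter half-life is expected, one that may not rise beyond the scatter. The estimated change is a 1.3-fold lower number from compound 1 to compound 3 (0.10 log units; within the scatter). For compound 3 the expected half-life is 0.8 h, within an estimated range of 0.35 h to 1.6 h.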

Compound 3, half-life in the liver assay: 0.35 h
For compound 3 the middle estimate is 2.3-fold (0.36 log units) above the measured one; the measured number falls inside the stated range.
By their numbers in the liver assay, from the lowest: compound 3; then compounds 1 and 2 (each within the scatter of the next).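

Among the compounds shown here, exchanging 3-oxomorpholin-4-yl for 4-methyl-2-oxopiperazin-1-yl gives the first readable step at this place: in the liver assay compound 1 gives 1.01 h and compound 3 gives 0.35 h, which is a 2.9-fold lower number from compound 1 to compound 3 (0.46 log units; beyond the scatter), and this shows that half-life at this position depends on the group carried there. The two compounds that could be compared before stood within the scatter of each other, whereas this change moves the number clearly. In a physicochemical assay for solubility, with a stated time of 18 h, at pH 7.4 (on this read-out higher numbers stand for higher solubility and lower numbers for lower solubility), compound 1 gives 21.9 ug/mL and compound 3 gives 28.9 ug/mL, and the same exchange gives a 1.3-fold higher number from compound 1 to compound 3 (0.12 log units; within the scatter), so compound 1 and compound 3 stand level on that read-out, and the change at this place separates them only on half-life; nothing at hand gives a reason for the shorter half-life.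

The compounds shown leave open which part of the new group goes with the step, as the ring nitrogen and its methyl enter together in a single exchange, and 2-oxopiperazin-1-yl without the methyl, or with an acetyl group on that nitrogen, would separate the two. They also leave open whether the same exchange would give a step of similar size on the fluorine-bearing ring of compound 2.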